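A few compounds are considered here, and "the series" means these few. Any claim that something is new, unique, unknown or untested is made for them only; others in the source may bear on it.

Compound 1, `COc1cc(-c2cc(/C=C/C(=O)c3ccc(N)cc3)[nH]n2)cc(OC)c1OC`, is measured in a functional assay on MDA-MB-435 cells (Homo sapiens) for cytotoxicity, read by sulforhodamine B assay, with a stated time of 48 h, tested at 1 uM (a higher number here means a weaker effect of the compound at the concentration tested, a lower number a stronger effect), where compound 1 gives 88%. Compound 2, `COc1ccc(C(=O)/C=C/c2cc(-c3cc(OC)c(OC)c(OC)c3)n[nH]2)cc1OC`, keeps the same core and gives 70%; the step of a number 18 percentage points lower from compound 1 to compound 2 (beyond the scatter) goes with a change of the ring attached to the carbonyl carbon. Among the two numbers so far, compound 2 stands lowest, with compound 1 the nearest and higher by a margin beyond the scatter. Compound 3, `COc1cc(C(=O)/C=C/c2cc(-c3cc(OC)c(OC)c(OC)c3)n[nH]2)cc(OC)c1OC`, differs from compound 2 in one place: methoxy in place of hydrogen on an aromatic carbon. Within the data shown here, only one measured step exists, and it swaps one whole ring for another rather than adding a methoxy group to a ring that already carries two, so it bears only weakly on this change. Without a step of the same kind to lean on, a step of a number 2 percentage points lower from compound 2 to compound 3 (within the scatter) is expected, small and within the scatter. Compound 3 is therefore estimated at 68%, in a range from 48% to 88%.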

Compound 3, a percentage reported as activity, at one concentration (the size of the read-out at that concentration, not a potency): 79%
Compound 3: the middle estimate sits 11 percentage points below what was measured; measured number inside the range.
By their numbers in this assay, from the lowest: compounds 2, 3 and 1 (each within the scatter of the next, the first and the last beyond it).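

Placing methoxy in place of hydrogen on an aromatic carbon, ortho to a methoxy group and meta to a large group, gives a number 9 percentage points higher from compound 2 to compound 3 (within the scatter) in this assay at the single concentration tested. Among these compounds, this is the first measured step that changes one group on a ring rather than swapping a whole ring, and at this position the added methoxy leaves compound 3 not distinguishable from compound 2. No measurement here speaks to why this change has so little visible effect.

From the compounds shown here alone, whether a hydroxyl group, a chlorine atom or an ethoxy group at this same position would move the read-out beyond the scatter remains open. Also open, going by these compounds, is how compound 2 and compound 3 would compare at other concentrations, since a single-concentration read-out is not a potency.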